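A few compounds are considered here, and "the series" means these few. Any claim that something is new, unique, unknown or untested is made for them only; others in the source may bear on it.

Measured so far in a physicochemical assay for solubility; on this read-out higher numbers stand for higher solubility and lower numbers for lower solubility:
compound 1, `CC(=O)N1CCc2c(C)c3c(n2-c2ccc(C(N)=O)c(c2)N[C@@H](C)CC1)CC(C)(C)CC3=O`: 19 ug/mL
compound 2, `CC(=O)NCCN1CC[C@H](C)Nc2cc(ccc2C(N)=O)-n2c(c(C)c3c2CC(C)(C)CC3=O)CC1=O`: > 100 ug/mL (a limit of the assay, not a number)

Among the compounds with values here, compound 1 is the only member of the series with a numerical read-out in this assay, where it gives 19 ug/mL. For compound 2 the entry is the limit of > 100 ug/mL in this assay, at which 1 of the 2 values shown sits, which marks a limit of the assay and not a measured point. Within the data shown here, no two measured compounds differ from each other in a single place, so no measured step is available to anchor an expectation.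

Compound 3, `CC(=O)NCC(=O)N1CCc2c(C)c3c(n2-c2ccc(C(N)=O)c(c2)N[C@@H](C)CC1)CC(C)(C)CC3=O`, remains to be measured. Set against compound 1, it differs in one place: acetamido in place of hydrogen on a saturated chain carbon bound to a carbonyl carbon. The entering acetamido group carries a hydrogen-bond donor and a hydrogen-bond acceptor and adds no charge.

Among the measured compounds shown here, with no measured step to go by, the step of a 2.4-fold higher number from compound 1 to compound 3 (0.37 log units; beyond the scatter) is expected to be an increase in this assay somewhat beyond the usual scatter, but of moderate size. Compound 3 is therefore estimated at 45 ug/mL, with a likely range from 15 ug/mL to 120 ug/mL.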

Compound 3, solubility: 5 ug/mL
The estimate for compound 3 lay 9.0-fold (0.95 log units) above the measured number; the measured number lies below the stated range.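

Acetamido in place of hydrogen on a saturated chain carbon bound to a carbonyl carbon, which turns the acetyl of compound 1 into the (acetamidomethyl)carbonyl of compound 3, gives a 3.8-fold lower number from compound 1 to compound 3 (0.58 log units; beyond the scatter) in this assay. Within the data shown here, this is the first measured step at this position, and it shows that the read-out responds to a change at this carbon and that the entering group, with its hydrogen-bond donor and acceptor and no net charge, goes with a lower number rather than a higher one. Nothing shown bears on the cause of this step, and compound 2, which differs from compound 1 in more than one place and stands at a limit of the assay, offers no comparison.

On these data alone, with a single step at this position, it remains open whether the lower number belongs to acetamido in particular or to substitution on this carbon in general. Also open, as far as these compounds go, is how a primary amine, a carboxylic acid or a longer chain ending in a hydroxyl group would read at the same place, and whether any of them would move the number upward from that of compound 1.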